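From Methyl to Benzyl on the Amide Nitrogen

A few compounds are considered here, and "the series" means these few. Any claim that something is new, unique, unknown or untested is made for them only; others in the source may bear on it.

Measured so far:
compound 1, `COC(=O)/C=C/c1cccc(N(Cc2ccc(-c3cccc(Cl)c3)cc2)C(=O)C2CCCCC2)c1`: 94 nM
compound 2, `COC(=O)/C=C/c1cccc(N(C)C(=O)C2CCCCC2)c1`: > 1000 nM

In an assay on isolated protein with Bile acid receptor (Homo sapiens) as the target (a higher number here means that more compound is needed for the effect, a lower number that less compound is needed), compound 1 gives 94 nM. Compound 2 gives only a limit in this assay, > 1000 nM, so its true value is not known, only that it sits at that limit (the limit of > 1000 nM in this assay, at which 1 of the 2 values shown sits). Compound 3, `COC(=O)/C=C/c1cccc(N(Cc2ccccc2)C(=O)C2CCCCC2)c1`, has not yet been measured. It differs from compound 2 by phenyl in place of hydrogen on a saturated chain carbon bound to an amide-type nitrogen. Within the data shown here, no step between measured compounds is available, and the starting point is a limit, so the size of the change can only be guessed. Compound 1, which carries a larger group on the same nitrogen, gives a clear number, and compound 3 carries part of that group. Compound 3 is therefore expected to move toward lower numbers, a step beyond the scatter an at least 2.0-fold lower number from compound 2 to compound 3 (0.30 log units; that floor lies within the scatter). Compound 3 is estimated at 500 nM, with a range from 150 nM to 2000 nM.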

Compound 3, half-maximal effective concentration: > 1000 nM
Compound 3 gave a limit, no number; the forecaster's own chance of this, stated with the estimate: 35%; at least 2.0-fold (0.30 log units) between middle value and limit.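

In this assay compound 3 gives > 1000 nM, which is a limit and not a number. The step from methyl to benzyl on the amide nitrogen cannot be read, because compound 2 sits at the same limit: the limit of > 1000 nM in this assay, at which 2 of the 3 values shown sit.

The readable change lies further out, where hydrogen in place of 3-chlorophenyl on an aromatic carbon gives an at least 10-fold higher number from compound 1 to compound 3 (1.02 log units; beyond the scatter), so a plain benzyl group on the nitrogen does not reproduce the clear result of compound 1, and the 3-chlorophenyl group makes the measurable difference here.

Still open, from the compounds shown here alone, is whether something much smaller on that aromatic carbon, such as a single chlorine atom or a methoxy group, would also give a clear number. Also open, going by these compounds, is how far compound 2 and compound 3 truly lie from each other.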